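Swapping a halogen for a methyl on the phenol ring

The source may report more compounds than this note shows. Statements on the series, on what has been measured and on what is new or still open speak of the compounds shown alone.

Compound 1, `CCC/N=C1\S/C(=C\c2ccc(O)c(Cl)c2)C(=O)N1c1ccccc1C`: 3.8
Compound 2, `CCC/N=C1\S/C(=C\c2ccc(O)c(Cl)c2)C(=O)N1C1CC1`: 3.4
Compound 3, `CCC/N=C1\S/C(=C\c2ccc(O)c(Br)c2)C(=O)N1c1ccccc1C`: 3.9

In a physicochemical assay for lipophilicity, read by HPLC, at pH 7.4 (a lower number here means a more polar compound, a higher number a more lipophilic compound), compound 3 gives the highest of the three numbers. Compound 1 sits closest to it, with a number 0.10 log units higher from compound 1 to compound 3 (within the scatter) lying within the scatter, so the two are not ordered. Compound 2 lies further off, and the gap between its value and that of compound 3 is beyond the scatter.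

Compound 4, `CCC/N=C1\S/C(=C\c2ccc(O)c(C)c2)C(=O)N1c1ccccc1C`, differs from compound 3 in one place: methyl in place of bromo on an aromatic carbon. The step that bears on this position is a number 0.10 log units higher from compound 1 to compound 3 (within the scatter), which was within the scatter. The other known step, a number 0.40 log units lower from compound 1 to compound 2 (beyond the scatter), concerns a different site and gives no guide here. Compound 4 is therefore expected to shift by a number 0.30 log units lower from compound 3 to compound 4 (within the scatter), a modest lowering. Compound 4 is estimated at 3.6, with a range from 3.3 to 3.9.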

Compound 4, distribution coefficient: 3.8
Beside the measured number, compound 4's estimate is 0.20 log units below it; measured number inside the range.
By their numbers in this assay, from the lowest: compound 2; then compounds 1, 4 and 3 (each within the scatter of the next).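

Read in this assay at this position, ortho to a hydroxy group, methyl in place of bromo gives a number 0.10 log units lower from compound 3 to compound 4 (within the scatter) and methyl in place of chloro gives no change at the digits printed from compound 1 to compound 4 (within the scatter) on the same core. Chloro, bromo and methyl therefore cannot be told apart here with the 2-methylphenyl group held in place. Nothing shown speaks to why these groups read alike.

Open, from the compounds shown here alone, is whether an amine or a carboxylic acid at this position would give a step beyond the scatter. Also open, going by these compounds, is whether methyl and chloro read alike with cyclopropyl in place of 2-methylphenyl.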